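A Carbonyl Gives Way to a Hydroxyl

This account rests on a few compounds, and the source may have more. Where it says the series, first, only, none or still open, it means among the compounds named here.

Of the compounds shown here, two have been tested in a functional assay on HCT-8 cells (Homo sapiens) for cytotoxicity, read by MTT assay; on this read-out lower numbers stand for stronger inhibition and higher numbers for weaker inhibition. Compound 1 `CC(C)[C@@H](O)C(=O)c1c[nH]c2ccccc12` carries a hydroxyketone directly on the shared core. In this assay compound 1 gives > 10000 nM, which is a limit of the assay rather than a number. Compound 2 `CC(C)(O)C(=O)Cc1cn([C@@H]2O[C@H](CO)[C@@H](O)[C@H](O)[C@H]2O)c2ccccc12` carries a (1-hydroxy-1-methylethyl)carbonyl on a saturated chain carbon bound to an aromatic carbon. In this assay compound 2 also reaches only a limit, > 10000 nM. Both results therefore sit at the limit of > 10000 nM in this assay, at which 2 of the 2 values shown sit, so neither compound shows measurable cytotoxicity within the tested range. Compound 3 `CC(C)(O)[C@@H](O)Cc1cn([C@@H]2O[C@H](CO)[C@@H](O)[C@H](O)[C@H]2O)c2ccccc12` differs from compound 2 in one place: 1,2-dihydroxy-2-methylpropyl in place of (1-hydroxy-1-methylethyl)carbonyl on a saturated chain carbon bound to an aromatic carbon. The carbonyl thus gives way to a second hydroxyl while the chain keeps its length. For the measured compounds named here, with both measured compounds stopping at the limit, there is no measured step to lean on, and the step that the limit leaves unreadable from compound 2 to compound 3 is expected to be essentially flat, with no shift beyond the scatter. In this assay compound 3 is therefore estimated at 20000 nM, within a range from 5000 nM to 100000 nM, and most likely reported once more as a limit.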

Compound 3, half-maximal inhibitory concentration: > 10000 nM
Compound 3: only a limit was reported (the forecaster's own chance of this, stated with the estimate: 80%); the middle value is on the limit's open side.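

In this assay compound 3 gives > 10000 nM, which is a limit of the assay and not a number. Compound 2 also stops at a limit, so no step can be read between compound 2 and compound 3, and all the results shown sit together: the limit of > 10000 nM in this assay, at which 3 of the 3 values shown sit. Still open, from the compounds shown here alone, is whether 1,2-dihydroxy-2-methylpropyl in place of (1-hydroxy-1-methylethyl)carbonyl changes the cytotoxicity at all.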